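Dimethylamino for Ethylamino, Tried on a Second Core

The source may hold more compounds than are shown below. What is called first, only, known or untested is meant among the compounds shown, and "the series" means these compounds.

Compound 1 `CCNCC(=O)Nc1cc(OC)ccc1C(=O)c1ccc(OC)c2c1C=CC(C)(C)O2` and compound 2 `COc1ccc(C(=O)c2ccc(OC)c3c2C=CC(C)(C)O3)c(NC(=O)CN(C)C)c1` differ only in one group: dimethylamino in place of ethylamino on a saturated chain carbon bound to a carbonyl carbon. In a functional assay on MCF7 cells (Homo sapiens) for antiproliferative activity, read by MTT assay, with a stated time of 48 h (on this read-out lower numbers stand for stronger inhibition and higher numbers for weaker inhibition), compound 1 gives 7230 nM and compound 2 gives 6530 nM, so that a 1.1-fold lower number from compound 1 to compound 2 (0.04 log units; within the scatter). Compound 3 `C=C(c1ccc(OC)cc1NC(=O)CNCC)c1ccc(OC)c2c1OC(C)(C)C=C2` rests on a different core; how the core of compound 3 differs from that of compound 1 is not broken down here. In this assay compound 3 gives 2100 nM, the lowest of the three numbers, with its steps to compound 2 and to compound 1 both beyond the scatter. Compound 4 `C=C(c1ccc(OC)cc1NC(=O)CN(C)C)c1ccc(OC)c2c1OC(C)(C)C=C2` stands to compound 3 as compound 2 stands to compound 1, through (dimethylamino in place of ethylamino on a saturated chain carbon bound to a carbonyl carbon), and it has not yet been measured. Because the same change earlier produced a 1.1-fold lower number from compound 1 to compound 2 (0.04 log units; within the scatter), the account expects the step from compound 3 to be about a 1.1-fold lower number from compound 3 to compound 4 (0.04 log units; within the scatter), again within the scatter. On that basis compound 4 is estimated to give about 1900 nM in this assay, with a likely range from 900 nM to 4000 nM.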

Compound 4, half-maximal inhibitory concentration: 500 nM
For compound 4 the middle estimate is 3.8-fold (0.58 log units) above the measured one; measured number below the stated range.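

In this assay, replacing ethylamino with dimethylamino gives a 4.2-fold lower number from compound 3 to compound 4 (0.62 log units; beyond the scatter), and this step does not match the one seen on the core of compound 1: the same change on two cores in this assay, a 1.1-fold lower number (0.04 log units; within the scatter) from compound 1 to compound 2 and a 4.2-fold lower number (0.62 log units; beyond the scatter) from compound 3 to compound 4, 3.8-fold (0.58 log units) apart, beyond the scatter of two such steps. In this series, then, the size of the step does not carry from one core to the other, and the near-absence of a step on the core of compound 1 gave no reliable guide to the result on the core of compound 3. The two pairs do not show why the cores differ, and they cannot tell how the same change would behave on a third core.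

The compounds shown leave open whether diethylamino, pyrrolidinyl or morpholinyl on the same saturated chain carbon would also separate the two cores. They also leave open whether a longer chain between the carbonyl carbon and the amine would keep, shrink or remove that difference.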